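A few compounds are considered here, and "the series" means these few. Any claim that something is new, unique, unknown or untested is made for them only; others in the source may bear on it.

Working notes on the series, read in a functional assay on DU-145 cells (Homo sapiens) for cytotoxicity, read by trypan blue exclusion, with a stated time of 96 h; on this read-out higher numbers stand for weaker inhibition and lower numbers for stronger inhibition. Compound 1 `COC(=O)C(F)(F)Nc1cc(CS(=O)(=O)/C=C/c2c(OC)cc(OC)cc2OC)ccc1OC` gives 250 nM, compound 2 `COC(=O)C(Nc1cc(CS(=O)(=O)/C=C/c2c(OC)cc(OC)cc2OC)ccc1OC)c1ccccc1` gives 75 nM and compound 3 `COC(=O)C(Nc1cc(CS(=O)(=O)/C=C/c2c(OC)cc(OC)cc2OC)ccc1OC)c1ccc(Br)cc1` gives 300 nM. Compound 3 cannot be told apart from compound 1, since a 1.2-fold higher number from compound 1 to compound 3 (0.08 log units; within the scatter) lies within the scatter. Compound 2 is separated from it, with a 4.0-fold higher number from compound 2 to compound 3 (0.60 log units; beyond the scatter) lying beyond the scatter.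

Next is compound 4 `COc1cc(OC)c(/C=C/S(=O)(=O)Cc2ccc(OC)c(NC(C(=O)O)c3ccc(F)cc3)c2)c(OC)c1`, with carboxy(4-fluorophenyl)methyl in place of (4-bromophenyl)(methoxycarbonyl)methyl on a nitrogen on an aromatic ring. The closest evidence on the halogen is the modest 4.0-fold higher number from compound 2 to compound 3 (0.60 log units; beyond the scatter), where bromo stands in place of hydrogen. For the measured compounds named here, no fluoro compound has been measured. Going by the values given here, no measured compound carries the free carboxy group either, so that part of the change has no precedent and could act in either direction. Other changes to the group on this nitrogen have also stayed modest, as with a 3.3-fold lower number from compound 1 to compound 2 (0.52 log units; beyond the scatter).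

No step beyond the scatter is therefore expected in this assay, though with wide uncertainty on both sides. The expected step is a 1.2-fold lower number from compound 3 to compound 4 (0.08 log units; within the scatter). The estimate for compound 4 is 250 nM, with an expected range of 60 nM to 1000 nM.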

Compound 4, half-maximal inhibitory concentration: 150 nM
Compound 4: the middle estimate sits 1.7-fold (0.22 log units) above what was measured; the measured number falls inside the stated range.
By their numbers in this assay, from the lowest: compounds 2, 4, 1 and 3 (each within the scatter of the next, the first and the last beyond it).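

In this assay, taking carboxy(4-fluorophenyl)methyl in place of (4-bromophenyl)(methoxycarbonyl)methyl on a nitrogen on an aromatic ring gives a step within the scatter (a 2.0-fold lower number from compound 3 to compound 4 (0.30 log units; within the scatter)), so this position tolerates a free carboxy group and a fluoro together without a separable change in the read-out. For the compounds shown here, compound 4 also lies within the scatter of the other two (a 2.0-fold higher number from compound 2 to compound 4 (0.30 log units; within the scatter); a 1.7-fold lower number from compound 1 to compound 4 (0.22 log units; within the scatter)), which makes it the only compound of the four not separated from any other, whereas compound 2 and compound 3 stand apart (a 4.0-fold higher number from compound 2 to compound 3 (0.60 log units; beyond the scatter)). Nothing available bears on the reason for this result.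

Going by these compounds, compound 4 differs from compound 3 in both the halogen and the ester at once, so the separate contributions of the fluoro and the free carboxy group stay open, and opposing contributions that cancel cannot be excluded. Also open, on these data alone, is how a primary amide in place of the carboxy group, or a chloro in place of the fluoro, would read in this assay.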